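Bromo in place of hydrogen on the core of compound 1

This account rests on a few compounds, and the source may have more. Where it says the series, first, only, none or still open, it means among the compounds named here.

Measured so far in a functional assay on the whole organism (strain STD-dd) with Mus musculus as the target, in the maximal electroshock model, with a stated time of 2 h; a higher number here means that more compound is needed for the effect, a lower number that less compound is needed:
compound 1 `CNS(=O)(=O)Cc1noc2ccccc12`: 23 mg/kg
compound 2 `CN(C)S(=O)(=O)Cc1noc2ccccc12`: 37 mg/kg

Compound 1 holds the lower of the two numbers, yet the step of a 1.6-fold higher number from compound 1 to compound 2 (0.21 log units; within the scatter) lies within the scatter, so the two compounds cannot be told apart. Compound 3 `CNS(=O)(=O)Cc1noc2ccc(Br)cc12` differs from compound 1 by bromo in place of hydrogen on an aromatic carbon. Among the measured compounds shown here, the only measured step, a 1.6-fold higher number from compound 1 to compound 2 (0.21 log units; within the scatter), concerns the sulfonamide nitrogen and gives no guide for a change on the aromatic ring. With nothing to lean on, no step beyond the scatter is expected. Compound 3 is estimated at 23 mg/kg, with a range of 10 mg/kg to 55 mg/kg. The expected step of no change at the digits printed from compound 1 to compound 3 (within the scatter) is thus no change beyond the scatter.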

Compound 3, dose for half-maximal effect: 15 mg/kg
The estimate for compound 3 lay 1.5-fold (0.19 log units) above the measured number; the measured number falls inside the stated range.
By their numbers in this assay, from the lowest: compounds 3, 1 and 2 (each within the scatter of the next, the first and the last beyond it).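

In this assay, the step of a 1.5-fold lower number from compound 1 to compound 3 (0.19 log units; within the scatter) shows that this aromatic carbon of the shared core accepts bromo in place of hydrogen without a change beyond the scatter. Among the compounds shown here, the earlier compounds varied only the sulfonamide nitrogen, so this is the first reading on the aromatic ring. Nothing available bears on the reason for this result.

Open, from the compounds shown here alone, is how an amine, a carboxylic acid or a longer chain would behave on this carbon. Also open, going by these compounds, is whether bromo would read the same on the other carbons of the ring.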